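The source may hold more compounds than are shown below. What is called first, only, known or untested is meant among the compounds shown, and "the series" means these compounds.

Compound 1 `Cc1cn(C)nc1Nc1cc2c(c(N)n1)c(C#N)c(N1CCC[C@H]1C)n2C` gives 63 nM in an assay on isolated protein for binding affinity to Leucine-rich repeat serine/threonine-protein kinase 2 (Homo sapiens), read by TR-FRET and LanthaScreen, with a stated time of 2 h; a lower number here means a stronger inhibitor, a higher number a weaker inhibitor. Going by the values given here, compound 2 `C[C@@H]1CCCN1c1c(C#N)c2c(N)nc(Nc3ccn(C)n3)cc2n1C` gives 6 nM in this assay and stands at the lowest number of the two; the only measured step, an 11-fold lower number from compound 1 to compound 2 (1.02 log units; beyond the scatter), separates it from compound 1. Compound 3 `C[C@@H]1CCCN1c1c(C#N)c2c(N)nccc2n1C` carries the change (hydrogen in place of (1-methyl-1H-pyrazol-3-yl)amino on an aromatic carbon). Among the compounds with values here, no measured step removes this group, so the step from compound 1 to compound 2 does not bear on it, and with the whole (1-methyl-1H-pyrazol-3-yl)amino group gone a large rise in the number is expected, a 170-fold higher number from compound 2 to compound 3 (2.22 log units; beyond the scatter). Compound 3 is therefore estimated at 1000 nM, within 150 nM to 10000 nM.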

Compound 3, inhibition constant: 0.8 nM
Compound 3: middle estimate off by 1300-fold (3.10 log units), on the high side, and the stated range ends above it.
By their numbers in this assay, from the lowest: compound 3; then compound 2; then compound 1.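

Hydrogen in place of (1-methyl-1H-pyrazol-3-yl)amino on the aromatic carbon next to the ring nitrogen gives a 7.5-fold lower number from compound 2 to compound 3 (0.88 log units; beyond the scatter) in this assay, and hydrogen in place of (1,4-dimethyl-1H-pyrazol-3-yl)amino gives a 79-fold lower number from compound 1 to compound 3 (1.90 log units; beyond the scatter). Among these three compounds, the pyrazolylamino groups are therefore not needed for a low number at this position, and the unsubstituted compound 3 stands lowest. No measured evidence here accounts for this result.

Going by these compounds, whether a small group on this carbon, such as an amine or a methyl, would keep the number as low as hydrogen remains open.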